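This account rests on a few compounds, and the source may have more. Where it says the series, first, only, none or still open, it means among the compounds named here.

Compound 3 `CNC(=O)[C@@]12C[C@@H]1[C@@H](n1cnc3c(NC)nc(C#Cc4ncccn4)nc31)[C@H](O)[C@@H]2O` gives the highest of the three numbers in an assay on CHO cells for displacement of a labelled ligand from adenosine receptor A1 (Homo sapiens), read by scintillation counting, with a stated time of 60 min, tested at 10 uM (a lower number here means less inhibition, a higher number more inhibition at the concentration tested (going by the name of the read-out)), with 25%. Compound 2 `CNC(=O)[C@@]12C[C@@H]1[C@@H](n1cnc3c(NC)nc(C#Cc4ccc(CO)cc4)nc31)[C@H](O)[C@@H]2O` gives 16% and compound 1 `CNC(=O)[C@@]12C[C@@H]1[C@@H](n1cnc3c(NC)nc(C#Cc4cccc(C(F)(F)F)c4)nc31)[C@H](O)[C@@H]2O` gives 10%. The steps at the group on the triple-bonded carbon were a number 15 percentage points higher from compound 1 to compound 3 (beyond the scatter), a number 9 percentage points higher from compound 2 to compound 3 (within the scatter) and a number 6 percentage points higher from compound 1 to compound 2 (within the scatter). Compound 4 `CNC(=O)[C@@]12C[C@@H]1[C@@H](n1cnc3c(NC)nc(C#Cc4cc5ccccc5o4)nc31)[C@H](O)[C@@H]2O` differs from compound 3 in the same place: 1-benzofuran-2-yl in place of pyrimidin-2-yl on a triple-bonded carbon. Because a number 15 percentage points higher from compound 1 to compound 3 (beyond the scatter) was the largest step seen at this position and only modest, no step beyond the scatter is expected here in this assay, in either direction. Compound 4 is therefore expected to give about 22%, within 8% to 38%. The expected step is a number 3 percentage points lower from compound 3 to compound 4 (within the scatter).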

Compound 4, a percentage reported as inhibition, at one concentration (the size of the read-out at that concentration, not a potency): 13%
Estimate against measurement, compound 4: 9 percentage points above; the measured number falls inside the stated range.
By their numbers in this assay, from the lowest: compounds 1, 4, 2 and 3 (each within the scatter of the next, the first and the last beyond it).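

In this assay the change to 1-benzofuran-2-yl gave a number 12 percentage points lower from compound 3 to compound 4 (beyond the scatter), so pyrimidin-2-yl now stands apart from two groups on this triple-bonded carbon rather than one. The two-ring group gave a number 3 percentage points higher from compound 1 to compound 4 (within the scatter) and a number 3 percentage points lower from compound 2 to compound 4 (within the scatter), leaving it within the scatter of both substituted phenyl groups. Nothing available explains these steps.

As far as these compounds go, it remains open whether pyridin-2-yl would group with pyrimidin-2-yl or with 1-benzofuran-2-yl. Also open, from the compounds shown here alone, is how an amine or a carboxylic acid on the ring would read here.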